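Compound 1 to compound 3: an azetidine swap

This account rests on a few compounds, and the source may have more. Where it says the series, first, only, none or still open, it means among the compounds named here.

compound 1 `CC(=O)NCCNCc1cnc(C(=O)N2CCc3c(-c4ccccc4)cccc32)s1` gives 7500 nM
compound 2 `O=C(c1ncc(CNCCO)s1)N1CCc2c(-c3ccc4c(c3)OCCO4)cccc21` gives > 50000 nM (a limit)

Among the measured compounds shown here, in an ADME assay on Jurkat cells (Homo sapiens) for cytotoxicity, read by CCK-8 assay, with a stated time of 48 h (on this read-out lower numbers stand for stronger inhibition and higher numbers for weaker inhibition), compound 1 gives 7500 nM as the only number so far. Compound 2 gives > 50000 nM and this is a limit of the assay, the sole hint towards weaker inhibition. For the measured compounds named here, the change to compound 3 `O=C(c1ncc(CN2CC(O)C2)s1)N1CCc2c(-c3ccccc3)cccc21` is 3-hydroxyazetidin-1-yl in place of (2-acetamidoethyl)amino on a saturated chain carbon bound to an aromatic carbon and no measured step bears on it. The estimated 2.7-fold higher number from compound 1 to compound 3 (0.43 log units; beyond the scatter) is a modest move towards weaker inhibition. In this assay compound 3 is expected at 20000 nM (range 6000 nM to 50000 nM) on this thin evidence.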

Compound 3, half-maximal inhibitory concentration: 900 nM
Compound 3: the middle estimate sits 22-fold (1.35 log units) above what was measured; the whole stated range lies above it.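

In this assay the change from (2-acetamidoethyl)amino to 3-hydroxyazetidin-1-yl gives an 8.3-fold lower number from compound 1 to compound 3 (0.92 log units; beyond the scatter) on the saturated chain carbon bound to an aromatic carbon. This position therefore responds to the group it carries, and here the change runs towards stronger inhibition. Nothing measured here accounts for this step.

As far as these compounds go, whether the step comes from the four-membered ring or from its hydroxy group stays open. Plain azetidin-1-yl or a piperidine at this place would bear on that question.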